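Penicillin-derived exocyclic enones and esters against OE19 cells

A few compounds are considered here, and "the series" means these few. Any claim that something is new, unique, unknown or untested is made for them only; others in the source may bear on it.

Compounds measured so far:
compound 1 `CC1(C)S[C@@H]2/C(=C\C(=O)c3ccc([N+](=O)[O-])cc3)C(=O)N2[C@H]1C(=O)OC(c1ccccc1)c1ccccc1`: 44100 nM
compound 2 `CC1(C)S[C@@H]2/C(=C\C(=O)OC(c3ccccc3)c3ccccc3)C(=O)N2[C@H]1C(=O)OC(c1ccccc1)c1ccccc1`: 21600 nM

In a functional assay on OE19 cells (Homo sapiens) for cytotoxicity, read by MTT assay, with a stated time of 48 h (on this read-out lower numbers stand for stronger inhibition and higher numbers for weaker inhibition), compound 1 gives 44100 nM, the highest of the two numbers recorded. Compound 2 gives 21600 nM in this assay, a lower number whose distance from compound 1 lies beyond the scatter of repeated runs. Compound 3 `COC(=O)/C=C1/C(=O)N2[C@@H]1SC(C)(C)[C@@H]2C(=O)OC(c1ccccc1)c1ccccc1` has not yet been measured in this assay. It differs from compound 1 in one place: methoxy in place of 4-nitrophenyl on a carbonyl carbon. Among the measured compounds shown here, no measured pair covers this exact change, so the size of the step is uncertain. On the shared core, compound 2 shows that a methoxycarbonyl-type replacement of the (4-nitrophenyl)carbonyl is compatible with a somewhat lower number, so a modest downward step is expected. The step from compound 1 to compound 3 is estimated as a 1.5-fold lower number from compound 1 to compound 3 (0.17 log units; within the scatter). Compound 3 is expected to give about 30000 nM in this assay, within a range from 10000 nM to 90000 nM.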

Compound 3, half-maximal inhibitory concentration: 20200 nM
Compound 3: the middle estimate sits 1.5-fold (0.17 log units) above what was measured, within the range that was stated.
By their numbers in this assay, from the lowest: compounds 3 and 2 (each within the scatter of the next); then compound 1.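

In this assay, methoxy in place of 4-nitrophenyl on the carbonyl carbon gives a 2.2-fold lower number from compound 1 to compound 3 (0.34 log units; beyond the scatter), showing that this position tolerates loss of the 4-nitrophenyl group and its aromatic ring without the number rising. Compound 3 at 20200 nM and compound 2 at 21600 nM lie within the scatter of each other, so the two esters cannot be separated on this read-out. Nothing measured here explains the step.

The compounds shown leave open whether the step follows from removing the 4-nitrophenyl group or from changing the ketone to an ester, since a plain phenyl ketone is not among them. From the compounds shown here alone, it also remains open how an amine or a carboxylic acid on this carbonyl carbon would compare with methoxy.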